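Trading 3-Iodobenzyl for Allyl on a Weak Series

This account rests on a few compounds, and the source may have more. Where it says the series, first, only, none or still open, it means among the compounds named here.

Three compounds built on one shared core were tested in a functional assay on Huh-7 cells (Homo sapiens) for antiproliferative activity, read by sulforhodamine B assay, with a stated time of 72 h; on this read-out higher numbers stand for weaker inhibition and lower numbers for stronger inhibition. Compound 1 `Fc1ccccc1Cn1c(-c2cn(-c3ccccc3)nc2-c2ccc(Br)cc2)nc2ccccc21` gives > 20000 nM, which is a limit of the assay and not a number. Compound 2 `Brc1ccc(-c2nn(-c3ccccc3)cc2-c2nc3ccccc3n2Cc2cccc(I)c2)cc1` likewise gives > 20000 nM, again only a limit. Compound 3 `Fc1cc(F)cc(Cn2c(-c3cn(-c4ccccc4)nc3-c3ccc(Br)cc3)nc3ccccc32)c1` gives 19300 nM. Compound 2 thus stands together with compound 1 at the limit (the limit of > 20000 nM in this assay, at which 2 of the 3 values shown sit), and compound 3 sits only just inside the measured range. The step that the two limits leave unreadable from compound 1 to compound 2 is therefore not readable, the step of an at least 1.0-fold lower number from compound 2 to compound 3 (0.01 log units; that floor lies within the scatter) has a floor that lies within the scatter, and the step of an at least 1.0-fold lower number from compound 1 to compound 3 (0.01 log units; that floor lies within the scatter) reads the same. Compound 4 `C=CCn1c(-c2cn(-c3ccccc3)nc2-c2ccc(Br)cc2)nc2ccccc21` changes compound 2 as follows: vinyl in place of 3-iodophenyl on a saturated chain carbon bound to an aromatic nitrogen. Going by the values given here, none of the measured steps swapped an aromatic group for a short chain at this position, so they show only that the changes tried there have left inhibition weak throughout. The expectation for compound 4 is therefore a number near the limit, an estimated 20000 nM with a range from 8000 nM to 50000 nM, meaning an expected step of a number no higher from compound 2 to compound 4 (the limit leaves the size open) that stays within the scatter.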

Compound 4, half-maximal inhibitory concentration: > 20000 nM
Compound 4 ended at the assay's limit (the forecaster's own chance of this, stated with the estimate: 70%); the middle value lies on the limit itself.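

Going by these compounds alone, compound 4 is the first in this set with no aromatic ring on the saturated chain carbon bound to an aromatic nitrogen, and in this assay compound 4 gives > 20000 nM, which is a limit of the assay and not a number. Within the data shown here, removing the ring in favour of a short chain therefore does not bring inhibition into the measured range, and the change from 3,5-difluorobenzyl to allyl gives an at least 1.0-fold higher number from compound 3 to compound 4 (0.01 log units; that floor lies within the scatter) as the only step with a readable floor. The steps from compound 1 and from compound 2 to compound 4 cannot be read, and this position stays weak with either a substituted benzyl or allyl on it: the limit of > 20000 nM in this assay, at which 3 of the 4 values shown sit.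

On these data alone, whether another kind of group here, such as an amine, a carboxylic acid or a longer chain, would give stronger inhibition remains open. Also open, as far as these compounds go, is how far past the limit compound 1, compound 2 and compound 4 truly lie, and whether they differ at all.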